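Thiophene for phenyl on the amide of compound 3

The source may report more compounds than this note shows. Statements on the series, on what has been measured and on what is new or still open speak of the compounds shown alone.

Compound 3 `CCCCCCCCCCCCCCCCCCNC(=O)[C@@H](NC(=O)c1ccccc1)[C@@H](C)O` carries a benzoyl group on the amine nitrogen of the core shared with compound 1 `CCCCCCCCCCCCCCCCCCNC(=O)[C@@H](N)[C@@H](C)O`. In a functional assay on HepG2 cells (Homo sapiens) for cytotoxicity, read by MTT assay, with a stated time of 48 h (on this read-out lower numbers stand for stronger inhibition and higher numbers for weaker inhibition), compound 1 gives 44500 nM. For compound 3 this assay reports only a limit, > 400000 nM. The step of an at least 8.9-fold higher number from compound 1 to compound 3 (0.95 log units; beyond the scatter) therefore shows that adding the benzoyl group pushes the number beyond the measured range, and this is documented as the limit of > 400000 nM in this assay, at which 1 of the 3 values shown sits. Compound 2 `CCCCCCCCNC(=O)[C@@H](NC(=O)c1cccs1)[C@@H](C)O` carries the thiophene-2-carbonyl group on a shorter chain; in this assay compound 2 gives 149000 nM. Compound 4 `CCCCCCCCCCCCCCCCCCNC(=O)[C@@H](NC(=O)c1cccs1)[C@@H](C)O` is not yet measured; it differs from compound 3 in this way: thiophen-2-yl in place of phenyl on a carbonyl carbon. Among the measured compounds shown here, no measured step tests the exchange of phenyl for thiophen-2-yl directly, and the only step that bears on the acylated nitrogen, an at least 8.9-fold higher number from compound 1 to compound 3 (0.95 log units; beyond the scatter), ends in a limit. The author expects no step beyond the scatter, an at least 1.1-fold lower number from compound 3 to compound 4 (0.05 log units; that floor lies within the scatter), for compound 4. The estimate for compound 4 in this assay is 350000 nM, ranging from 120000 nM to 1000000 nM.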

Compound 4, half-maximal inhibitory concentration: 92000 nM
Compound 4: middle estimate off by 3.8-fold (0.58 log units), on the high side; the measured number lies below the stated range.
By their numbers in this assay, from the lowest: compound 1; then compounds 4 and 2 (each within the scatter of the next). At a limit, above all of these: compound 3.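

In this assay, thiophen-2-yl in place of phenyl on a carbonyl carbon gives an at least 4.3-fold lower number from compound 3 to compound 4 (0.63 log units; beyond the scatter), so this position does respond to the exchange of the ring. That step is only a floor, since the value for compound 3 is a limit of the assay and not a number: the limit of > 400000 nM in this assay, at which 1 of the 4 values shown sits. With (thiophen-2-yl)carbonyl on the amine nitrogen, the core of compound 1 shows a 2.1-fold higher number from compound 1 to compound 4 (0.32 log units; beyond the scatter), a modest step, while decyl in place of hydrogen on the chain gives a 1.6-fold lower number from compound 2 to compound 4 (0.21 log units; within the scatter), so with this acyl group the longer chain brings no change beyond the scatter.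

The compounds shown leave open how furan-2-yl or pyridin-2-yl would read on this carbonyl carbon. They also leave open how a dodecyl chain would read with the (thiophen-2-yl)carbonyl group in place.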